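Aryl substituent swap at the aniline terminus

The compounds below may be only part of what the source reports. "The series", "measured", "known", "first", "only" and "open" are said of these compounds alone.

Measured compounds, with their values in a functional assay on CHOK cells for antagonist activity at growth hormone secretagogue receptor type 1 (Homo sapiens), read by calcium flux; on this read-out higher numbers stand for weaker inhibition and lower numbers for stronger inhibition:
- compound 1 `CCc1nc(N)nc(N)c1-c1ccc(NCc2cc(F)c(S(C)(=O)=O)c(F)c2)cc1` gives 45 nM
- compound 2 `CCc1nc(N)nc(N)c1-c1ccc(CNc2ccc([N+](=O)[O-])cc2)cc1` gives 190 nM
- compound 3 `CCc1nc(N)nc(N)c1-c1ccc(CNc2ccc(S(C)(=O)=O)cc2)cc1` gives 120 nM

Compound 3 stands second highest of the three numbers in this assay. Its nearest neighbour is compound 2, separated by a step within the scatter; furthest is compound 1, whose number is lower than that of compound 3 by a gap beyond the scatter. Within the data shown here, compound 1 carries a different linker and substitution pattern, and no single-point step connects it to compound 3.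

Compound 4 `CCc1nc(N)nc(N)c1-c1ccc(CNc2ccc(Cl)cc2)cc1` differs from compound 3 in one place: chloro in place of methylsulfonyl on an aromatic carbon. Among the measured compounds shown here, the only measured step on this aromatic carbon is a 1.6-fold lower number from compound 2 to compound 3 (0.20 log units; within the scatter), an exchange of one group for another that stayed within the scatter. For the measured compounds named here, no measured step exchanges methylsulfonyl for chloro, so the expectation rests on that single swap and on the shared core. A step of a 1.5-fold higher number from compound 3 to compound 4 (0.18 log units; within the scatter) is expected, with no direction beyond the scatter called with confidence. For compound 4 the estimate in this assay is 180 nM, within 60 nM to 550 nM.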

Compound 4, half-maximal inhibitory concentration: 3150 nM
Estimate against measurement, compound 4: 18-fold (1.24 log units) below; measured number above the stated range.
By their numbers in this assay, from the lowest: compound 1; then compounds 3 and 2 (each within the scatter of the next); then compound 4.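

At this aromatic carbon, para to a large group, the identity of the substituent can matter greatly in this assay: chloro gives a 26-fold higher number from compound 3 to compound 4 (1.42 log units; beyond the scatter) and also a 17-fold higher number from compound 2 to compound 4 (1.22 log units; beyond the scatter) on replacing nitro. The swap from nitro to methylsulfonyl had stayed within the scatter, so that pair alone gave no sign of such sensitivity at this position. Compound 4 now stands apart from both compound 2 and compound 3, while those two remain within the scatter of each other. Nothing at hand bears on what separates chloro from the other two groups.

Whether the loss is specific to chloro remains open, as the compounds shown include no amine, carboxylic acid, or methyl group at this carbon. Also open, from the compounds shown here alone, is whether the different linker of compound 1 would respond to chloro in the same way.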